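Dropping the Chlorine: Expected Potency of Compound 4

This account rests on a few compounds, and the source may have more. Where it says the series, first, only, none or still open, it means among the compounds named here.

Measured so far:
Compound 1, `Cc1ccc(N2CC(c3nc(-c4cccc(C(F)(F)F)c4)no3)CC2=O)cc1`: 3400 nM
Compound 2, `O=C1CC(c2nc(-c3ccccc3)no2)CN1c1ccccc1`: 350 nM
Compound 3, `Cc1ccc(N2CC(c3nc(-c4cccc(Cl)c4)no3)CC2=O)cc1`: 630 nM

These three compounds were tested in an in vitro functional assay on HEK293-A cells for positive allosteric modulation of metabotropic glutamate receptor 5 (Homo sapiens), read by FLIPR and calcium flux; on this read-out higher numbers stand for an effect only at larger amounts of compound and lower numbers for an effect already at smaller amounts. Compound 3 gives the second highest number of the three in this assay, at 630 nM. Its nearest neighbour is compound 2, whose 350 nM lies within the scatter of compound 3; its furthest is compound 1 at 3400 nM, beyond the scatter.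

Compound 4, `Cc1ccc(N2CC(c3nc(-c4ccccc4)no3)CC2=O)cc1`, has not yet been measured. It differs from compound 3 by hydrogen in place of chloro on an aromatic carbon, so the 3-chlorophenyl becomes a plain phenyl. Within the data shown here, one measured step touches this position: a 5.4-fold lower number from compound 1 to compound 3 (0.73 log units; beyond the scatter). That step shows a smaller group giving a lower number. Compound 2 also carries a plain phenyl here, though it differs from compound 3 elsewhere as well, and its value sits within the scatter of compound 3.

For compound 4, a small drop is therefore expected in this assay, a 1.6-fold lower number from compound 3 to compound 4 (0.20 log units; within the scatter), though it may stay within the scatter. Compound 4 is estimated at 400 nM, with a range from 150 nM to 1200 nM.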

Compound 4, half-maximal effective concentration: 384 nM
Compound 4: the middle estimate sits 1.0-fold (0.02 log units) above what was measured, within the range that was stated.
By their numbers in this assay, from the lowest: compounds 2, 4 and 3 (each within the scatter of the next); then compound 1.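

In this assay, taking away the chloro gives a 1.6-fold lower number from compound 3 to compound 4 (0.22 log units; within the scatter), so the chlorine on this aromatic carbon can be removed without a change that stands clear of the scatter, whereas taking away the trifluoromethyl gives an 8.9-fold lower number from compound 1 to compound 4 (0.95 log units; beyond the scatter), which sets trifluoromethyl apart from both hydrogen and chloro at this position. The methyl can now be read on its own too: adding it gives a 1.1-fold higher number from compound 2 to compound 4 (0.04 log units; within the scatter), so this change also stays within the scatter. No other kind of measurement is available to explain these steps.

As far as these compounds go, only hydrogen, chloro and trifluoromethyl appear at this position, so it remains open how a methoxy group, a fluorine or an amine would behave there. From the compounds shown here alone, it also remains open whether the methyl would still make so little difference with chloro or trifluoromethyl in place.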